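The source may report more compounds than this note shows. Statements on the series, on what has been measured and on what is new or still open speak of the compounds shown alone.

Measured in a functional assay on DU-145 cells (Homo sapiens) for cytotoxicity, read by MTT assay, with a stated time of 48 h; a higher number here means a weaker inhibitor, a lower number a stronger inhibitor:
- compound 1 `C=C/C(C)=C\CC/C(C)=C/c1cc(C(=O)O)co1`: 60100 nM
- compound 2 `C=C/C(C)=C\CC/C(C)=C/c1cc(C(=O)OC)co1`: 59300 nM

Among the compounds with values here, only two numbers are available so far, and compound 2, at 59300 nM, sits level with compound 1 within the scatter. Compound 3 `C=C/C(C)=C\CC/C(C)=C/c1cc(C(=O)Nc2ccc(C)cc2)co1` differs from compound 2 by (4-methylphenyl)amino in place of methoxy on a carbonyl carbon. Within the data shown here, one measured step bears on this change, since it also concerns the group on that carbonyl carbon. That step, methyl in place of hydrogen on an oxygen, is a 1.0-fold lower number from compound 1 to compound 2 (0.01 log units; within the scatter). It shows that one small exchange left the number unchanged, but it involved no ring and no amide hydrogen, so it gives only weak guidance for a much larger substituent. Among the measured compounds shown here, no measured compound carries such a group. A moderate move towards a lower number in this assay is therefore expected, held with little confidence, and no change at all remains possible. The estimated step is a 1.8-fold lower number from compound 2 to compound 3 (0.25 log units; within the scatter). For compound 3 the estimated value is 33000 nM, with an expected range from 11000 nM to 90000 nM.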

Compound 3, half-maximal inhibitory concentration: 56500 nM
Compound 3: the middle estimate sits 1.7-fold (0.23 log units) below what was measured; low and high end bracket the measured number.
By their numbers in this assay, from the lowest: compounds 3, 2 and 1 (each within the scatter of the next).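

In this assay, (4-methylphenyl)amino on the carbonyl carbon reads level with methoxy (a 1.0-fold lower number from compound 2 to compound 3 (0.02 log units; within the scatter)) and level with hydroxy (a 1.1-fold lower number from compound 1 to compound 3 (0.03 log units; within the scatter)). The earlier pair had exchanged only a hydrogen for a methyl on an oxygen, whereas this change brings in 8 heavy atoms, one six-membered aromatic ring of carbon only and 1 hydrogen-bond donor, and the number still stays within the scatter, so all three groups on this carbonyl carbon now read alike, even at very different sizes. No evidence is at hand that would account for this level reading.

Going by these compounds, whether it extends to other groups on the same carbonyl carbon stays open, for instance a simple amine such as dimethylamino, a longer alkyl chain on the amide nitrogen, or a methyl in place of the amide hydrogen. On these data alone, the three compounds also share one unchanged core and side chain, so what a shorter chain or a hydroxyl group on that chain would do to the number remains unknown here.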